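The source may hold more compounds than are shown below. What is called first, only, known or untested is meant among the compounds shown, and "the series" means these compounds.

Among the measured compounds shown here, in a functional assay on MGC-803 cells (Homo sapiens) for inhibition, read by MTT assay, with a stated time of 48 h (on this read-out lower numbers stand for stronger inhibition and higher numbers for weaker inhibition), compound 1 `CCCCC(=O)N(Cc1ccc(OC)c(O)c1)c1cc(OC)c(OC)c(OC)c1` gives 66 nM, the lowest of the two actual numbers available so far. Compound 2 `COc1ccc(CNc2cc(OC)c(OC)c(OC)c2)cc1Cl` gives 46200 nM, a gap from compound 1 well beyond the usual scatter of repeated measurements. Compound 3 `COc1cc(NCc2ccc(Cl)cc2)cc(OC)c1OC` reads > 80000 nM, which is a limit of the assay and not a number.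

The next compound, compound 4 `C/C=C/C=C/C(=O)N(Cc1ccc(OC)c(O)c1)c1cc(OC)c(OC)c(OC)c1`, keeps the core of compound 1 and alters only the chain on the carbonyl carbon: penta-1,3-dien-1-yl in place of butyl on a carbonyl carbon. Penta-1,3-dien-1-yl takes the place of butyl, on a carbonyl carbon whose other neighbour is an amide-type nitrogen. For the measured compounds named here, no measured pair here shows what this swap does, so the expectation in this assay is only a rough one, and its range is wide. Starting from compound 1 at 66 nM, a small move towards a higher number is expected, possibly none beyond the scatter. The estimated change is a 1.8-fold higher number from compound 1 to compound 4 (0.26 log units; within the scatter). Compound 4 is expected to give about 120 nM, with an estimated range from 25 nM to 600 nM.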

Compound 4, half-maximal inhibitory concentration: 140 nM
For compound 4 the middle estimate is 1.2-fold (0.07 log units) below the measured one, within the range that was stated.
By their numbers in this assay, from the lowest: compound 1; then compound 4; then compound 2. At a limit, above all of these: compound 3.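

In this assay, among the compounds shown here, the change gives the first direct reading at this position, where two compounds differ only in the chain on the carbonyl carbon: penta-1,3-dien-1-yl in place of butyl gives a 2.1-fold higher number from compound 1 to compound 4 (0.33 log units; beyond the scatter). The step is modest, so within this single pair, a chain with one more carbon and two double bonds is tolerated with only a small loss, and the amide-type nitrogen and the rest of the core of compound 1 stay unchanged. Nothing measured here accounts for the size or direction of this step.

The pair cannot separate the effect of the double bonds from that of the extra carbon, and a saturated pentyl chain on the same carbonyl carbon would tell them apart. As far as these compounds go, how an amine, a carboxylic acid or a much longer chain would behave in this place also remains open.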